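A Fluorophenyl Urea in Place of a Benzyl Urea

A few compounds are considered here, and "the series" means these few. Any claim that something is new, unique, unknown or untested is made for them only; others in the source may bear on it.

For the measured compounds named here, compound 1 `COc1ccc(-c2cnc3nc(N)nc(N4CCN(C(=O)NCc5ccccc5)CC4)c3n2)cc1OC` is the one compound of the three that gives a number in a functional assay on cells (T-cell, Homo sapiens) for inhibition; a higher number here means a weaker inhibitor, a lower number a stronger inhibitor: compound 1 reads 18 nM. Compound 2 `CCOc1nc(N)nc2ncc(-c3ccc(OC)cc3)nc12` sits at the limit of > 10000 nM in this assay, at which 2 of the 3 values shown sit. In this assay compound 2 gives > 10000 nM, a limit of the assay rather than a number. Compound 3 `COc1ccc(-c2cnc3nc(N)nc(OC(C)C)c3n2)cc1` stands at the same limit, and in this assay compound 3 gives > 10000 nM. Going by the values given here, the one step between measured compounds that differ in one place, a step that the two limits leave unreadable from compound 2 to compound 3, concerns methyl in place of hydrogen on a saturated chain carbon bound to an oxygen on an aromatic ring and a saturated chain carbon, and its size cannot be read. Compound 4 `COc1ccc(-c2cnc3nc(N)nc(N4CCN(C(=O)Nc5ccc(F)cc5)CC4)c3n2)cc1OC` differs from compound 1 in one place: 4-fluorophenyl in place of benzyl on an amide-type nitrogen. Among the compounds with values here, no measured step touches this amide-type nitrogen, so the data give no direction for the change. The step is therefore expected to stay within the scatter, a 1.1-fold higher number from compound 1 to compound 4 (0.05 log units; within the scatter). Compound 4 is estimated at 20 nM, between 6 nM and 65 nM.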

Compound 4, half-maximal inhibitory concentration: 7 nM
The estimate for compound 4 lay 2.9-fold (0.46 log units) above the measured number, within the range that was stated.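

Setting 4-fluorophenyl in place of benzyl on the amide-type nitrogen gives the first readable step at this position: in this assay, the change is a 2.6-fold lower number from compound 1 to compound 4 (0.41 log units; beyond the scatter). The earlier compounds shown here offered no step here, and this one shows that inhibition does not depend on the benzyl group, since 4-fluorophenyl is accepted on this nitrogen with a modest gain. Nothing measured in the data bears on the origin of this step.

The compounds shown leave open how much of the step belongs to the fluorine and how much to the change from benzyl to a phenyl ring, which plain phenyl or 4-fluorobenzyl on the same nitrogen would separate. They also leave open how a different group on this nitrogen, such as cyclohexyl or a longer chain, would read.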